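The compounds below may be only part of what the source reports. "The series", "measured", "known", "first", "only" and "open" are said of these compounds alone.

Working notes on the shared core. Compound 1 `C=C1C[C@]23C[C@@]1(O)CC[C@H]2c1ccc(O)c(C)c1[C@@H]3Cn1cc(-c2ccccn2)nn1` in a functional assay on A549 cells (Homo sapiens) for cytotoxicity, read by MTT assay, with a stated time of 4 days (on this read-out lower numbers stand for stronger inhibition and higher numbers for weaker inhibition), gives > 20000 nM, which is a limit of the assay. Compound 2 `C=C1C[C@]23C[C@@]1(O)CC[C@H]2c1ccc(O)c(C)c1[C@@H]3Cn1cc(-c2ccc(Br)cc2)nn1` in this assay gives > 20000 nM, again a limit. The step from these two, a step that the two limits leave unreadable from compound 1 to compound 2, lies between two limits and cannot be read. Compound 3 `C=C1C[C@]23C[C@@]1(O)CC[C@H]2c1cc(Br)c(O)c(C)c1[C@@H]3Cn1cc(-c2ccc(F)cc2)nn1` in this assay gives 17900 nM, the only number shown. The other two values sit at the limit of > 20000 nM in this assay, at which 2 of the 3 values shown sit. Compound 4 `C=C1C[C@]23C[C@@]1(O)CC[C@H]2c1ccc(O)c(C)c1[C@@H]3Cn1cc(-c2ccc(F)cc2)nn1` differs from compound 3 by hydrogen in place of bromo on an aromatic carbon. For the measured compounds named here, no measured step covers this change; the single readable-looking comparison concerns a different position and is itself unreadable. Expected: no step beyond the scatter, a 1.7-fold higher number from compound 3 to compound 4 (0.22 log units; within the scatter), with a fair chance that only a limit is reported. Compound 4 is estimated at 30000 nM in this assay, within 12000 nM to 80000 nM.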

Compound 4, half-maximal inhibitory concentration: > 20000 nM
Compound 4 was reported as a limit (the forecaster's own chance of this, stated with the estimate: 55%); the middle value does not contradict the limit.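

In this assay, for the compounds shown here, this is the first readable comparison at the position ortho to the hydroxy group: hydrogen in place of bromo gives an at least 1.1-fold higher number from compound 3 to compound 4 (0.04 log units; that floor lies within the scatter). On these data alone, that floor neither shows nor excludes a contribution from the bromo group here, and the true size of the step remains unknown. The steps among compound 1, compound 2 and compound 4 cannot be read, and most of the series sits at one limit: the limit of > 20000 nM in this assay, at which 3 of the 4 values shown sit.

As far as these compounds go, it remains open whether an amine or a carboxylic acid at this position would give a number clear of that limit. From the compounds shown here alone, the effect of bromo at this position with a pyridin-2-yl group in place of the 4-fluorophenyl group also remains open.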